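The source may hold more compounds than are shown below. What is called first, only, known or untested is meant among the compounds shown, and "the series" means these compounds.

Working notes on the series. In a functional assay on SW480 cells (Homo sapiens) for cytotoxicity, read by MTT assay, with a stated time of 72 h (a lower number here means a stronger inhibitor, a higher number a weaker inhibitor), two compounds have been run so far, and both sit at the same limit of the assay. Compound 1, `Cc1nnc(SCc2cc(=O)c3cc(Cl)ccc3o2)o1`, gives in this assay the limit > 25000 nM, a limit rather than a number. Compound 2, `Nc1nnc(SCc2cc(=O)c3ccccc3o2)s1`, gives in this assay the limit > 25000 nM, again a limit and not a measured value. So compound 2 stands at the ceiling of what this assay reports, with nothing to rank it against: the limit of > 25000 nM in this assay, at which 2 of the 2 values shown sit, describes the whole picture, and no single step between measured compounds exists to lean on.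

Compound 3, `Nc1nnc(SCc2cc(=O)c3cc(Cl)ccc3o2)s1`, differs from compound 2 by chloro in place of hydrogen on an aromatic carbon. With only limits in hand, no direction can be read off; the expectation for the change from compound 2 to compound 3 is a step no larger than the scatter, a step that the limit leaves unreadable from compound 2 to compound 3, and most likely another limit. On that basis compound 3 is estimated at 40000 nM in this assay, within a range from 20000 nM to 100000 nM, with the measurement expected to return only a limit.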

Compound 3, half-maximal inhibitory concentration: > 25000 nM
Compound 3: no number, only a limit (the forecaster's own chance of this, stated with the estimate: 85%); the middle value does not contradict the limit.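

In this assay compound 3 gives > 25000 nM, a limit and not a number, so neither step to compound 3, from compound 1 or from compound 2, can be read. The series stands at one value: the limit of > 25000 nM in this assay, at which 3 of the 3 values shown sit.

The compounds shown leave open what chloro in place of hydrogen, or the exchange of the group on the sulfur, does in this assay.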